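Phenyl in Place of Propyl on the Chain Carbon

The source may hold more compounds than are shown below. What is called first, only, known or untested is meant among the compounds shown, and "the series" means these compounds.

Compound 1 `CCC/C(=C\C=C\C(=O)N[C@H](C)CCCc1cccnc1)c1ccc(OC)cc1`: 50 nM
Compound 2 `O=C(C/C=C/C=C(c1ccccc1)c1ccccc1)NCCCCc1cccnc1`: 55 nM

Both compounds were tested in an assay (Canis lupus familiaris) for binding affinity to platelet-activating factor receptor (Homo sapiens), read by radioligand binding; a lower number here means a stronger inhibitor, a higher number a weaker inhibitor. Compound 1 gives the lowest of the two numbers, yet the value of compound 2 lies within the scatter of it, so no order between the two can be claimed. For the measured compounds named here, their structures differ in more than one place and no single step between them is available, so only their two values can be set side by side.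

Compound 3 `COc1ccc(/C(=C/C=C/C(=O)N[C@H](C)CCCc2cccnc2)c2ccccc2)cc1` has not yet been measured. It arises from compound 1 by phenyl in place of propyl on a double-bonded chain carbon bound to an aromatic carbon and a double-bonded chain carbon. Compound 2 carries two phenyl groups on its double-bonded chain carbon and gives a number close to that of compound 1, which suggests that the exchange of propyl for phenyl does not move the number far. The step is therefore expected to stay within the scatter, with no clear direction: a 1.1-fold lower number from compound 1 to compound 3 (0.05 log units; within the scatter). In this assay compound 3 is estimated at 45 nM, with a range from 15 nM to 140 nM.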

Compound 3, half-maximal inhibitory concentration: 2 nM
Compound 3: the middle estimate sits 23-fold (1.35 log units) above what was measured; the whole stated range lies above it.
By their numbers in this assay, from the lowest: compound 3; then compounds 1 and 2 (each within the scatter of the next).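

In this assay, putting phenyl in place of propyl on a double-bonded chain carbon bound to an aromatic carbon and a double-bonded chain carbon gives a 25-fold lower number from compound 1 to compound 3 (1.40 log units; beyond the scatter), which shows that the number responds strongly to the group carried at this position. The two earlier compounds could not show this: compound 1 and compound 2 differ in more than one place, and although compound 2 also carries phenyl on this carbon, it differs from compound 3 in more than one place too, so its value cannot be read against this step. No available measurement accounts for the size of this step.

On these data alone, whether the lower number belongs to phenyl in particular or would also follow from another group on this carbon, such as cyclohexyl, benzyl, pyridyl or a chain longer than propyl, remains open, since a single step cannot separate these cases. The compounds shown also leave open whether a step of similar size would appear if the methoxy group of compound 3 were replaced by a hydroxyl group or a fluorine atom.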